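The compounds below may be only part of what the source reports. "The series", "measured", "known", "first", "only" and "open" are said of these compounds alone.

Going by the values given here, compound 3 `C/C(CC(=O)Nc1nnc(-c2ccc(O)cc2)s1)=N\c1ccccn1` gives 3.43 in a physicochemical assay for lipophilicity, measured as octanol-water partition (on this read-out lower numbers stand for lower lipophilicity and higher numbers for higher lipophilicity), the second highest of the three numbers measured so far; compound 1 `C/C(CC(=O)Nc1nnc(-c2ccc([N+](=O)[O-])cc2)s1)=N\c1ccc([N+](=O)[O-])cn1` gives 3.54 and compound 2 `C/C(CC(=O)Nc1nnc(-c2ccc(N)cc2)s1)=N\c1ccc([N+](=O)[O-])cn1` gives 3.21, both within the scatter of compound 3. Compound 4 `C/C(CC(=O)Nc1nnc(-c2ccc(O)cc2)s1)=N\c1ccc([N+](=O)[O-])cn1` differs from compound 3 in one place: nitro in place of hydrogen on an aromatic carbon. Among the compounds with values here, the only measured step in this assay, a number 0.33 log units lower from compound 1 to compound 2 (beyond the scatter), also involves a nitro group, but exchanges it for amino rather than for hydrogen, so it bears on the present change only loosely. A nitro group entering in place of hydrogen is therefore expected to move this assay little, a step estimated as a number 0.07 log units higher from compound 3 to compound 4 (within the scatter). Compound 4 is accordingly estimated at 3.5, expected to fall between 3.2 and 3.8.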

Compound 4, partition coefficient: 3.34
Estimate against measurement, compound 4: 0.16 log units above; measured number inside the range.
By their numbers in this assay, from the lowest: compounds 2, 4, 3 and 1 (each within the scatter of the next, the first and the last beyond it).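

In this assay, the change from pyridin-2-yl to 5-nitropyridin-2-yl gives a number 0.09 log units lower from compound 3 to compound 4 (within the scatter) with hydroxy on the other aromatic ring, so this position takes nitro without a step beyond the scatter. With 5-nitropyridin-2-yl kept, the exchanges give a number 0.13 log units higher from compound 2 to compound 4 (within the scatter) and a number 0.20 log units lower from compound 1 to compound 4 (within the scatter) for hydroxy in place of amino and of nitro, placing hydroxy within the scatter of both, though those two groups differ beyond it. No measurement at hand gives a reason for these steps. Open remains how an amine or a carboxylic acid would behave at the nitro position, and whether the hydrogen-to-nitro step stays this size with amino or nitro in place of hydroxy.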